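The source may report more compounds than this note shows. Statements on the series, on what has been measured and on what is new or still open speak of the compounds shown alone.

Measured so far:
Compound 1 `O=C1C=CCC/C1=C\C=C\c1ccccc1` gives 4500 nM
Compound 2 `CC(=C\c1ccccc1)/C=C1\CCC=CC1=O` gives 5200 nM

Both numbers come from a functional assay on HGC-27 cells (Homo sapiens) for cytotoxicity, read by MTT assay, with a stated time of 72 h (on this read-out lower numbers stand for stronger inhibition and higher numbers for weaker inhibition), and compound 2 at 5200 nM lies within the scatter of compound 1, so the pair is not separated.

The next compound is compound 3 `O=C1C=CCC/C1=C\C(Br)=C\c1ccccc1`, with the change (bromo in place of methyl on a double-bonded chain carbon bound to two double-bonded chain carbons), that is, bromo in place of methyl on a double-bonded chain carbon bound to two double-bonded chain carbons.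

Within the data shown here, only one measured step bears on this place. It is a 1.2-fold higher number from compound 1 to compound 2 (0.06 log units; within the scatter), methyl in place of hydrogen, and it stays within the scatter. Among the measured compounds shown here, no bromo compound has yet been measured in this assay, so that step gives only indirect guidance and the range has to stay wide. The change at this place is therefore expected to stay small, with no step beyond the scatter. The estimated step is a 1.3-fold lower number from compound 2 to compound 3 (0.11 log units; within the scatter) and it carries no firm direction. For compound 3 the expected value is 4000 nM, with an estimated range from 1500 nM to 9000 nM.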

Compound 3, half-maximal inhibitory concentration: > 10000 nM
Compound 3: a limit, no number; the forecaster's own chance of this, stated with the estimate: 3%; middle value at least 2.5-fold (0.39 log units) from the limit.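

In this assay, compound 3 reads as a limit and not a number: the limit of > 10000 nM in this assay, at which 1 of the 3 values shown sits. Bromo in place of hydrogen on the double-bonded chain carbon bound to two double-bonded chain carbons gives an at least 2.2-fold higher number from compound 1 to compound 3 (0.34 log units; beyond the scatter), the first step in this short series beyond the scatter, so this position is not indifferent to every substitution, although methyl in place of hydrogen left compound 1 and compound 2 unseparated. Bromo in place of methyl gives an at least 1.9-fold higher number from compound 2 to compound 3 (0.28 log units; that floor lies within the scatter); this is only a floor, so on its own it does not separate the pair, and the size of the real step may be larger.

The limit leaves the full size of both bromo steps unknown, and one bromo compound cannot show whether the weaker inhibition belongs to bromo alone or extends to other groups at this place. As far as these compounds go, whether chloro, methoxy, an amine or a longer chain on this chain carbon would stay with hydrogen and methyl or move with bromo remains open.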